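A Methoxyphenyl Swap on a Core That Reaches Only a Limit

The compounds below may be only part of what the source reports. "The series", "measured", "known", "first", "only" and "open" are said of these compounds alone.

Compound 1 `Cc1cnc(Nc2ccc(C(C)C)cc2)nc1Nc1nc2ccccc2s1`: > 50000 nM
Compound 2 `Cc1cnc(Nc2ccc(S(C)(=O)=O)cc2)nc1Nc1nc2ccccc2s1`: > 50000 nM
Compound 3 `CS(=O)(=O)c1ccc(Nc2nccc(Nc3nc4ccc(F)cc4s3)n2)cc1`: 1940 nM

In a functional assay on PC-3 cells (Homo sapiens) for antiproliferative activity, read by MTT assay, with a stated time of 48 h (a lower number here means a stronger inhibitor, a higher number a weaker inhibitor), compound 1 stands only at the limit, > 50000 nM. Compound 2 also stands at the limit, > 50000 nM. Compound 3 gives 1940 nM, but compound 3 differs from compound 1 in more than one place, so its value cannot be tied to a single change. Among the compounds with values here, the only measured step, a step that the two limits leave unreadable from compound 1 to compound 2, cannot be read because of the limit of > 50000 nM in this assay, at which 2 of the 3 values shown sit. Compound 4 is `COc1cccc(Nc2ncc(C)c(Nc3nc4ccccc4s3)n2)c1`; it differs from compound 1 by 3-methoxyphenyl in place of 4-isopropylphenyl on a nitrogen on an aromatic ring. Within the data shown here, no measured step bears on this change, so the expected step of a number no higher from compound 1 to compound 4 (the limit leaves the size open) is taken as none beyond the scatter. Compound 4 is therefore expected near 50000 nM, between 8000 nM and 200000 nM, most likely again reported only as a limit.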

Compound 4, half-maximal inhibitory concentration: > 50000 nM
Compound 4 gave a limit, no number; the forecaster's own chance of this, stated with the estimate: 60%; the middle value sits exactly at the limit.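

Within the data shown here, compound 1 and compound 4 both give only a limit in this assay, and no step between them can be read: the limit of > 50000 nM in this assay, at which 3 of the 4 values shown sit. The compounds shown leave open how far compound 1 and compound 4 truly lie apart in this assay.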